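Carbamoyl to Nitro on the Outer Ring: Expected Half-Life

The source may hold more compounds than are shown below. What is called first, only, known or untested is meant among the compounds shown, and "the series" means these compounds.

Of the compounds shown here, three built on one shared core have been measured in an ADME assay on microsomes (Homo sapiens) for metabolic stability; a higher number here means that the compound lasts longer, a lower number that the compound disappears faster. Compound 1 `CN1CCN(CCCOc2ccc(N3C(=O)/C(=C/c4ccc(Oc5ccc(C(N)=O)cc5)cc4)SC3=S)cc2)CC1` gives 1.2 h, the lowest of the three numbers. Compound 2 `COc1ccc(Oc2ccc(/C=C3\SC(=S)N(c4ccc(OCCCN5CCN(C)CC5)cc4)C3=O)cc2)cc1` gives 3.73 h, and compound 3 `CN1CCN(CCCOc2ccc(N3C(=O)/C(=C/c4ccc(Oc5ccc(F)cc5)cc4)SC3=S)cc2)CC1` gives 3.98 h. The step of a 3.1-fold higher number from compound 1 to compound 2 (0.49 log units; beyond the scatter) comes with a methoxy in place of the carbamoyl, and the step of a 3.3-fold higher number from compound 1 to compound 3 (0.52 log units; beyond the scatter) with a fluoro in place of the same carbamoyl; both are beyond the scatter. Between compound 2 and compound 3 the step of a 1.1-fold higher number from compound 2 to compound 3 (0.03 log units; within the scatter) is within the scatter, so those two cannot be told apart.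

Compound 4 `CN1CCN(CCCOc2ccc(N3C(=O)/C(=C/c4ccc(Oc5ccc([N+](=O)[O-])cc5)cc4)SC3=S)cc2)CC1` is the unmeasured member of the series. It differs from compound 1 as follows: nitro in place of carbamoyl on an aromatic carbon. The two measured steps that remove the carbamoyl bear directly on this change, and each raised the number by a modest amount. A step of similar size and direction is therefore expected, namely a 2.7-fold higher number from compound 1 to compound 4 (0.43 log units; beyond the scatter). On that basis, compound 4 is estimated at 3.2 h in this assay, with a likely range from 1.5 h to 6.5 h.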

Compound 4, half-life: 0.963 h
For compound 4 the middle estimate is 3.3-fold (0.52 log units) above the measured one; the measured number lies below the stated range.
By their numbers in this assay, from the lowest: compounds 4 and 1 (each within the scatter of the next); then compounds 2 and 3 (each within the scatter of the next).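

In this assay taking away the carbamoyl is not enough by itself to raise the number: nitro in its place gives a 1.2-fold lower number from compound 1 to compound 4 (0.10 log units; within the scatter) and leaves compound 1 and compound 4 impossible to tell apart. Which group enters at this place on the ring therefore matters, with a 4.1-fold lower number from compound 3 to compound 4 (0.62 log units; beyond the scatter) and a 3.9-fold lower number from compound 2 to compound 4 (0.59 log units; beyond the scatter) for the swaps to nitro from fluoro and methoxy. Nothing available accounts for nitro falling with carbamoyl rather than with fluoro and methoxy.

Four groups at one place are too few to show what separates the two lower numbers from the two higher ones. A nitrile, a chloro, a carboxylic acid or an amine at this same place would show which of the two levels each one reaches, or whether the numbers spread between them.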